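Adding a second ring group to compound 1

A few compounds are considered here, and "the series" means these few. Any claim that something is new, unique, unknown or untested is made for them only; others in the source may bear on it.

Measured so far in an ADME assay on L6 cells (Rattus norvegicus) for cytotoxicity; a higher number here means a weaker inhibitor, a lower number a stronger inhibitor:
- compound 1 `c1ccc(Sc2ccc(NC3=NCCN3)cc2)cc1`: 28500 nM
- compound 2 `O=S(=O)(c1ccc(NC2=NCCN2)cc1)c1ccc(NC2=NCCN2)cc1`: > 196000 nM (a limit)

Among the compounds with values here, compound 1, at 28500 nM, holds the only exact number so far. Compound 3 `c1cc(Sc2ccc(NC3=NCCN3)cc2)ccc1NC1=NCCN1` is compound 1 with one change: a group of 6 heavy atoms (3 carbon, 3 nitrogen; one five-membered non-aromatic ring with 2 hetero atoms) in place of a hydrogen atom, on an aromatic carbon. The new group sits on an aromatic carbon, para to a large group. Within the data shown here, no measured pair shows this change alone. Compound 2 also carries two such groups, and its > 196000 nM is a limit. On that basis, a sizeable step toward a higher number in this assay, meaning a weaker effect, is expected. For compound 3 the estimated value is 90000 nM, within an expected range of 28000 nM to 230000 nM.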

Compound 3, half-maximal inhibitory concentration: 23300 nM
Estimate against measurement, compound 3: 3.9-fold (0.59 log units) above; measured number outside the range, below it.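

In this assay the five-membered ring group on the aromatic carbon, para to a large group, brings a 1.2-fold lower number from compound 1 to compound 3 (0.09 log units; within the scatter) so this position takes the added group without a readable change. A second such ring group alone therefore does not carry the number upward. Compound 2 also holds two of these groups, and its value is only a limit: the limit of > 196000 nM in this assay, at which 1 of the 3 values shown sits.

Going by these compounds, it remains open how an amine or a carboxylic acid would read on this same aromatic carbon. On these data alone, a longer chain in place of the ring group is equally open.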